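Taking the Acyl Group off Compound 3

A few compounds are considered here, and "the series" means these few. Any claim that something is new, unique, unknown or untested is made for them only; others in the source may bear on it.

In an ADME assay on cells (Hepatocyte, Homo sapiens) for metabolic stability, with a stated time of 30 min (on this read-out higher numbers stand for a more stable compound and lower numbers for a less stable compound), compound 3 (`O=C(OC1CCC(CN2CCN(c3cc(=O)c4cc(C(F)(F)F)cc([N+](=O)[O-])c4s3)CC2)CC1)c1ccc(C(F)(F)F)cc1`) gives 5.2%. That is within the scatter of compound 2 (`CC(=O)OC1CCC(CN2CCN(c3cc(=O)c4cc(C(F)(F)F)cc([N+](=O)[O-])c4s3)CC2)CC1`) at 0%, and lower, beyond the scatter, than compound 1 (`O=c1cc(N2CCN(CC3CCCCC3)CC2)sc2c(NO)cc(C(F)(F)F)cc12`) at 19.1%. Compound 4 (`O=c1cc(N2CCN(CC3CCC(O)CC3)CC2)sc2c([N+](=O)[O-])cc(C(F)(F)F)cc12`) carries hydrogen in place of (4-(trifluoromethyl)phenyl)carbonyl on an oxygen on a saturated carbon. Among the measured compounds shown here, the one measured step bearing on this is a number 5.2 percentage points higher from compound 2 to compound 3 (within the scatter), and it keeps the carbonyl, so the data do not show what losing it does. Compound 1 also lacks that carbonyl and stands at 19.1%, but it differs elsewhere too. A modest rise is therefore expected, estimated as a number 9.8 percentage points higher from compound 3 to compound 4 (within the scatter). For compound 4 the estimated value is 15%, within an expected range of 2% to 40%.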

Compound 4, percent of the compound remaining: 72.7%
Beside the measured number, compound 4's estimate is 57.7 percentage points below it; measured number above the stated range.
By their numbers in this assay, from the lowest: compounds 2 and 3 (each within the scatter of the next); then compound 1; then compound 4.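

In this assay the loss of the acyl group from the oxygen on a saturated carbon matters greatly, whichever acyl group leaves: the step is a number 67.5 percentage points higher from compound 3 to compound 4 (beyond the scatter) for (4-(trifluoromethyl)phenyl)carbonyl and a number 72.7 percentage points higher from compound 2 to compound 4 (beyond the scatter) for acetyl. Exchanging one acyl group for the other had moved the number only within the scatter (a number 5.2 percentage points higher from compound 2 to compound 3 (within the scatter)), so across these compounds the large change comes with removing the acyl group, not with varying it. Nothing shown gives a reason for this rise.

From the compounds shown here alone, whether the gain requires the hydroxyl itself or only the absence of an ester stays open. A methyl ether or an amine on that saturated carbon would separate the two.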